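This account rests on a few compounds, and the source may have more. Where it says the series, first, only, none or still open, it means among the compounds named here.

The measured compounds, each with its number in a functional assay on the whole organism (strain albino) for inhibition, with Rattus norvegicus as the target, read by paw edema, with stated times of 30 min and 3 h, at a dose of 50 mg/kg by the oral route; a higher number here means more inhibition at the dose given (going by the name of the read-out), a lower number less inhibition:

compound 1 `COc1cc(/C=N/CC2CCCO2)ccc1O` gives 14%
compound 2 `COc1cc(/C=N/CCCn2ccnc2)ccc1O` gives 0%

Compound 2 stands lowest of the two numbers. Its nearest neighbour is compound 1, whose value is higher by a gap beyond the scatter. Going by the values given here, no step between measured compounds that differ in one place is available, so the two values show only that compound 2 sits below compound 1.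

Compound 3 `COc1cc(/C=N/CCN2CCNCC2)ccc1O` is not yet measured. It differs from compound 2 in one place: piperazin-1-yl in place of (1H-imidazol-1-yl)methyl on a saturated chain carbon, two bonds along the chain from a double-bonded nitrogen. Among the compounds with values here, there is no measured step that would show what this change does, and the measured pair does not share it. The expected change in this assay is small, upward if anything, and likely within the scatter: a number 8 percentage points higher from compound 2 to compound 3 (within the scatter). Compound 3 is therefore expected to give about 8%, with a range from 0% to 25%.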

Compound 3, a percentage reported as inhibition, in the whole organism at one dose (the size of the read-out at that dose, not a potency): 18%
Compound 3: middle estimate off by 10 percentage points, on the low side; the measured number falls inside the stated range.
By their numbers in this assay, from the lowest: compound 2; then compounds 1 and 3 (each within the scatter of the next).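

In this assay, the group on this saturated chain carbon proves able to move the read-out: piperazin-1-yl in place of (1H-imidazol-1-yl)methyl gives a clear change (a number 18 percentage points higher from compound 2 to compound 3 (beyond the scatter)). The two groups match in heavy atoms, with 4 carbon and 2 nitrogen each, and in their 2 hydrogen-bond acceptors, but they differ in ring type, and piperazin-1-yl brings 1 hydrogen-bond donor where the other group has 0. Nothing available explains the step or shows which of these differences matters.

As far as these compounds go, it remains open whether a morpholine ring or a dimethylamine at this position would give a number like that of compound 3 or that of compound 2. A longer chain carrying piperazin-1-yl is equally untested by these compounds, and a single oral dose gives the size of the effect, not a potency.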